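A few compounds are considered here, and "the series" means these few. Any claim that something is new, unique, unknown or untested is made for them only; others in the source may bear on it.

Three compounds have been measured in an ADME assay (liver, Mus musculus) for metabolic stability, using microsomes; on this read-out lower numbers stand for a shorter-lived compound and higher numbers for a longer-lived compound:

Compound 1 `CCc1nc2ccc(Cl)cn2c1C(=O)NCc1ccc(-c2ccccc2Cl)cc1`: 0.218 h
Compound 2 `CCc1nc2cc(Cl)ccn2c1C(=O)NCc1ccc(-c2ccc(Cl)cc2)cc1`: > 1 h
Compound 3 `CCc1nc2cc(Cl)ccn2c1C(=O)NCc1ccc(N2CCCCC2)cc1`: 0.0383 h

Compound 2 stands at > 1 h, which is a limit of the assay and not a number. Within the data shown here, it is the only compound of the three at the limit of > 1 h in this assay, at which 1 of the 3 values shown sits, so its true half-life is not known.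

Compound 4 `CCc1nc2cc(Cl)ccn2c1C(=O)NCc1ccc(-n2cc3c(c2)CCCC3)cc1` has not yet been measured. It differs from compound 2 by this change: a group of 9 heavy atoms (8 carbon, 1 nitrogen; one five-membered aromatic ring with 1 hetero atom, one six-membered non-aromatic ring of carbon only) in place of a group of 7 heavy atoms (6 carbon, 1 chlorine; one six-membered aromatic ring of carbon only), on an aromatic carbon. The 4-chlorophenyl leaves the aromatic carbon, and a group with one five-membered aromatic ring with 1 hetero atom and one six-membered non-aromatic ring of carbon only takes its place.

Among the measured compounds shown here, one measured step bears on this, since compound 3 also gives up the 4-chlorophenyl at that place. That step is large and beyond the scatter: an at least 26-fold lower number from compound 2 to compound 3 (1.41 log units; beyond the scatter). For the measured compounds named here, compound 1 differs from compound 2 in more than one place and offers no such step. Going by the values given here, with only one precedent and a different entering group, the size remains uncertain, but a clear fall is expected. The estimated change is an at least 8.3-fold lower number from compound 2 to compound 4 (0.92 log units; beyond the scatter).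

For compound 4 the expected half-life in this assay is 0.12 h, with an estimated range of 0.035 h to 0.5 h.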

Compound 4, half-life: 1.04 h
Compound 4: middle estimate off by 8.7-fold (0.94 log units), on the low side, and the stated range ends below it.
By their numbers in this assay, from the lowest: compound 3; then compound 1; then compound 4.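

At this place, on an aromatic carbon para to a large group, this assay had so far shown only one replacement for the 4-chlorophenyl, and that piperidin-1-yl gave an at least 26-fold lower number from compound 2 to compound 3 (1.41 log units; beyond the scatter). The entering group of compound 4, with its five-membered aromatic ring and its six-membered non-aromatic ring of carbon only, gives a 27-fold higher number from compound 3 to compound 4 (1.43 log units; beyond the scatter), so giving up the 4-chlorophenyl does not in itself go with a short half-life, and the outcome at this place depends on the group that takes its place. Compound 2 stands at a limit of the assay and not at a number, so the step from it to compound 4 cannot be read: the limit of > 1 h in this assay, at which 1 of the 4 values shown sits.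

The groups of compound 3 and compound 4 differ both in the aromatic ring and in the fused carbon ring, so the compounds shown do not tell which of these features goes with the higher number. A plain pyrrol-1-yl and a cyclohexyl at this place would separate the two, and a morpholin-4-yl would show how far the low number of compound 3 extends to other saturated amines.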